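This account rests on a few compounds, and the source may have more. Where it says the series, first, only, none or still open, it means among the compounds named here.

Working notes on a short urea series.

Of the compounds shown here, two have numbers so far. Compound 1 `C[C@@H](NC(=O)Nc1ccccc1F)c1ccccc1` and compound 2 `C[C@@H](NC(=O)Nc1ccc(F)cc1)c1ccccc1` share the same core and differ only in where the single fluoro sits on the aniline ring. In an ADME assay on the whole organism with Oryza sativa as the target, tested at 1 uM (on this read-out lower numbers stand for a stronger effect and higher numbers for a weaker effect at the one concentration tested), compound 1 gives 95%. In this assay compound 2 gives 96%. Compound 2 holds the higher of the two numbers, but its nearest neighbour, compound 1, lies within the scatter of it, so the two readings are taken as equal for present purposes and no order between them is claimed. Both numbers sit at the weak end of the read-out.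

The next compound, compound 3 `C[C@@H](NC(=O)Nc1ccc(F)cc1F)c1ccccc1`, follows from compound 2 by fluoro in place of hydrogen on an aromatic carbon. The change adds one fluorine and nothing else; the fluoro already present in compound 2 stays in place.

Among the compounds with values here, no step between measured compounds has been computed here, and the two numbers available show no difference beyond the scatter. For compound 3 no step beyond the scatter is expected in this assay, and the estimated change is a number 2 percentage points lower from compound 2 to compound 3 (within the scatter). Compound 3 is estimated at 94%, with a range of 82% to 100%.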

Compound 3, a percentage reported as activity, at one concentration (the size of the read-out at that concentration, not a potency): 100%
For compound 3 the middle estimate is 6 percentage points below the measured one, within the range that was stated.
By their numbers in this assay, from the lowest: compounds 1, 2 and 3 (each within the scatter of the next).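

In this assay, fluoro in place of hydrogen on the aromatic carbon ortho to a large group and meta to a fluoro group gives a number 4 percentage points higher from compound 2 to compound 3 (within the scatter) and so leaves no step beyond the scatter at this position. The other step into compound 3, also fluoro in place of hydrogen on an aromatic carbon, gives a number 5 percentage points higher from compound 1 to compound 3 (within the scatter) and likewise stays within the scatter, so a second fluoro on the ring adds nothing readable to what the two single-fluoro compounds showed, and all three readings remain at the weak end of the read-out. No measurement at hand bears on why these readings stay together.

The compounds shown carry only fluoro as a ring substituent, so they leave open whether a larger or different group on this same aromatic carbon, such as a methoxy, an amine or a carboxylic acid, would give a step beyond the scatter. They also leave open whether any change away from this ring, such as a longer chain in place of the methyl on the shared core, would move the read-out at all.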